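Removing one trifluoromethyl from a diaryl urea

A few compounds are considered here, and "the series" means these few. Any claim that something is new, unique, unknown or untested is made for them only; others in the source may bear on it.

Compound 1 `O=C(Nc1cccc(-n2cc(-c3ccncc3)c(-c3cc(O)cc(Cl)c3)n2)c1)Nc1ccc(Cl)c(C(F)(F)F)c1`: 95%
Compound 2 `COc1cc(Cl)cc(-c2nn(-c3cccc(NC(=O)Nc4cc(C(F)(F)F)cc(C(F)(F)F)c4)c3)cc2-c2ccncc2)c1`: 97%

In a functional assay on Hs-578T cells (Homo sapiens) for inhibition, read by sulforhodamine B assay, with a stated time of 48 h, tested at 0.01 uM (on this read-out lower numbers stand for a stronger effect and higher numbers for a weaker effect at the one concentration tested), compound 2 gives 97%, and compound 1 gives 95%; the two numbers sit within the usual scatter of each other, so neither compound can be set above the other on this read-out. Compound 3 `COc1cc(Cl)cc(-c2nn(-c3cccc(NC(=O)Nc4cccc(C(F)(F)F)c4)c3)cc2-c2ccncc2)c1` differs from compound 2 in one place: hydrogen in place of trifluoromethyl on an aromatic carbon. Among the measured compounds shown here, no measured pair shows the effect of such a change here, so the step from compound 2 to compound 3 is expected to stay within the scatter, with no clear direction, giving a number 1 percentage points lower from compound 2 to compound 3 (within the scatter). Compound 3 is therefore estimated at 96%, in the range 87% to 103%.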

Compound 3, a percentage reported as activity, at one concentration (the size of the read-out at that concentration, not a potency): 99%
For compound 3 the middle estimate is 3 percentage points below the measured one, within the range that was stated.
By their numbers in this assay, from the lowest: compounds 1, 2 and 3 (each within the scatter of the next).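

Swapping one trifluoromethyl for hydrogen on this aromatic carbon gives, in this assay, a number 2 percentage points higher from compound 2 to compound 3 (within the scatter). Among the compounds shown here, at the one concentration tested, this is the first direct sign that the read-out does not separate the two compounds, so this position shows no clear response to losing the group. No available information explains this outcome.

Still open, from the compounds shown here alone, is whether an amine, a carboxylic acid or a longer chain on this carbon would move the number beyond the scatter. Also open, going by these compounds, is what would happen if the remaining trifluoromethyl were replaced by hydrogen.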